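A Pyridine Ring in Place of Fluorophenyl

The source may hold more compounds than are shown below. What is called first, only, known or untested is meant among the compounds shown, and "the series" means these compounds.

Compound 1 `Cc1ncc([N+](=O)[O-])n1CCSc1nnc(-c2ccccc2F)o1` and compound 2 `COc1cc(OC)cc(-c2nnc(SCCn3c([N+](=O)[O-])cnc3C)o2)c1` share a common core and differ only in the aromatic group attached to it. In a functional assay on HepG2 cells (Homo sapiens) for cytotoxicity, read by MTT assay, with a stated time of 48 h (a lower number here means a stronger inhibitor, a higher number a weaker inhibitor), compound 1 gives 3700 nM, the lower of the two numbers recorded so far, while compound 2 gives 10500 nM, and the gap between them lies beyond the usual scatter of repeated measurements. Compound 3 `Cc1ncc([N+](=O)[O-])n1CCSc1nnc(-c2ccncc2)o1` has not yet been measured. Compared with compound 1, the change is pyridin-4-yl in place of 2-fluorophenyl on an aromatic carbon. Within the data shown here, no pair of measured compounds shows this same exchange, so there is no measured step to lean on, and the comparison with compound 2 concerns a different group. The expectation is that the step of a 1.5-fold higher number from compound 1 to compound 3 (0.17 log units; within the scatter) is small, toward a somewhat higher number, and close to the edge of the scatter. Compound 3 is therefore expected to give about 5500 nM, with a likely range from 1800 nM to 17000 nM.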

Compound 3, half-maximal inhibitory concentration: 14800 nM
Estimate against measurement, compound 3: 2.7-fold (0.43 log units) below; the measured number falls inside the stated range.
By their numbers in this assay, from the lowest: compound 1; then compounds 2 and 3 (each within the scatter of the next).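

In this assay the exchange of 2-fluorophenyl for pyridin-4-yl brings a 4.0-fold higher number from compound 1 to compound 3 (0.60 log units; beyond the scatter) and gives this position its first measured step. The step is modest but beyond the scatter, so on this aromatic carbon of the five-membered aromatic ring, the choice of six-membered aromatic ring does change the reading, and the ring with a nitrogen goes with the weaker number of this pair. No measurement shown here accounts for the step.

The exchange removes the fluorine and brings in the ring nitrogen together, so a plain phenyl group on the same core would be needed to tell those two changes apart. A pyridin-3-yl group would show whether the place of the ring nitrogen matters as well.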